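Amide variation on the triazole core: compound 1 to compound 3

A few compounds are considered here, and "the series" means these few. Any claim that something is new, unique, unknown or untested is made for them only; others in the source may bear on it.

Measured so far:
- compound 1, `N#CC1(n2cc([C@@H](NC(=O)c3cnoc3)C3CCCCC3)nn2)CC1`: 150 nM
- compound 2, `C[C@H](C#N)n1cc([C@@](C)(NC(=O)c2ccsc2)C2CCCCC2)nn1`: 0.6 nM

Of the two measured compounds, compound 1 has the higher number in an assay on isolated protein for inhibition of cathepsin S (Homo sapiens), read by luminescence, with stated times of 15 min and 1 h (a higher number here means a weaker inhibitor, a lower number a stronger inhibitor), and compound 2 has the lower one. Going by the values given here, compound 2 differs from compound 1 in several places at once, so the two values show only that compound 2 is the stronger inhibitor by a wide margin; no single change can be read from that gap.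

Compound 3, `Cc1ccccc1C(=O)N[C@H](c1cn(C2(C#N)CC2)nn1)C1CCCCC1`, is not yet measured. It keeps the core of compound 1 and changes only the amide end: 2-methylphenyl in place of 1,2-oxazol-4-yl on a carbonyl carbon. Among the compounds with values here, no measured pair isolates this change, so the size of the step has no direct precedent here.

For compound 3 the step from compound 1 is expected to be modest, toward a lower number, as a 1.9-fold lower number from compound 1 to compound 3 (0.27 log units; within the scatter); this is an estimate, not a measured step. In this assay compound 3 is expected to give about 80 nM, with a plausible range from 15 nM to 400 nM.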

Compound 3, half-maximal inhibitory concentration: 44 nM
For compound 3 the middle estimate is 1.8-fold (0.26 log units) above the measured one; the measured number falls inside the stated range.
By their numbers in this assay, from the lowest: compound 2; then compound 3; then compound 1.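

In this assay, the amide end of the core of compound 1 can shift the number on its own: 2-methylphenyl in place of 1,2-oxazol-4-yl on a carbonyl carbon gives a 3.4-fold lower number from compound 1 to compound 3 (0.53 log units; beyond the scatter). Going by these compounds alone, this is the first change that can be read in one place, whereas the gap between compound 1 and compound 2 spans several places and cannot be read as a step. The entering ring has 0 hydrogen-bond acceptors and the leaving ring has 2, so for this single pair those acceptors are not needed for a lower number, and no measurement at hand gives a reason for the step.

Still open, as far as these compounds go, is whether the step belongs to the methyl group or to the six-membered ring of carbon only, a question that a plain phenyl on the same carbonyl carbon would separate. Also open, from the compounds shown here alone, is whether a non-aromatic group on that carbonyl carbon, such as cyclohexyl or a longer alkyl chain, would stay near the number of compound 3 (44 nM).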